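A few compounds are considered here, and "the series" means these few. Any claim that something is new, unique, unknown or untested is made for them only; others in the source may bear on it.

Measured in an ADME assay on CCRF-HSB-2 cells (Homo sapiens) for cytotoxicity, with a stated time of 7 days; on this read-out lower numbers stand for higher toxicity in this test and higher numbers for lower toxicity in this test:
- Compound 1 `CSc1nc(N)nc2c1ncn2/C=C1/CC1(CO)CO`: > 100000 nM
- Compound 2 `CCCCSc1nc(N)nc2c1ncn2/C=C1/CC1(CO)CO`: 89000 nM

The entry of compound 1, > 100000 nM, is a limit of the assay and not a number. For the measured compounds named here, compound 2 gives 89000 nM, the only true number available in this assay, so it serves as the starting point here.

Compound 3 `Nc1nc(SCc2ccccc2)c2ncn(/C=C3/CC3(CO)CO)c2n1` keeps the shared core and changes only the group on the sulfur. The difference is phenyl in place of propyl on a saturated chain carbon bound to a sulfur, which turns butylsulfanyl into benzylsulfanyl.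

One measured step changes the same place: an at least 1.1-fold lower number from compound 1 to compound 2 (0.05 log units; that floor lies within the scatter). That step gives only a floor for its size, and that floor is small. With so little to go on, compound 2 at 89000 nM remains the best anchor, and no clear direction can be drawn from the data.

The estimated step, a 1.3-fold lower number from compound 2 to compound 3 (0.10 log units; within the scatter), is expected to stay within the usual scatter. Compound 3 is expected at about 70000 nM, with an estimated range of 25000 nM to 100000 nM.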

Compound 3, half-maximal cytotoxic concentration: > 100000 nM
Compound 3: a limit, no number (the forecaster's own chance of this, stated with the estimate: 35%); at least 1.4-fold (0.15 log units) between middle value and limit.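

In this assay compound 3 gives > 100000 nM, which is a limit of the assay and not a number. Phenyl in place of propyl on a saturated chain carbon bound to a sulfur, which turns butylsulfanyl into benzylsulfanyl, gives an at least 1.1-fold higher number from compound 2 to compound 3 (0.05 log units; that floor lies within the scatter), so a six-membered aromatic ring at this place does not bring the number down in this test, although the true size of the step stays unknown and its floor alone cannot separate the two compounds. Because compound 1 and compound 3 both end at a limit, the step between them cannot be read: the limit of > 100000 nM in this assay, at which 2 of the 3 values shown sit.

On these data alone, it remains open how far the values of compound 1 and compound 3 lie past the limit, and whether any change at this place can move the number beyond the usual scatter. As far as these compounds go, what an amine or a carboxylic acid on the chain bound to the sulfur, or a chain longer than butyl, would do to this read-out also stays open.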